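Fluoro for Chloro on the Benzyl Arm

This account rests on a few compounds, and the source may have more. Where it says the series, first, only, none or still open, it means among the compounds named here.

Three compounds share one core and differ only in the group attached through the amine. Compound 1 `NC(N)=NC(=O)c1nc(Cl)c(NCc2ccccc2Cl)nc1N` carries a benzyl arm bearing a 2-chlorophenyl group; compound 2 `NC(N)=NC(=O)c1nc(Cl)c(NC2CC2)nc1N` carries a cyclopropyl group instead; compound 3 `NC(N)=NC(=O)c1nc(Cl)c(Nc2cnc3ccccc3c2)nc1N` carries a larger aromatic substituent bound directly to the core.

In an assay for inhibition of acid-sensing ion channel 3 (Homo sapiens), read by patch clamp, tested at 20 uM (on this read-out higher numbers stand for more inhibition at the one concentration tested (going by the name of the read-out) and lower numbers for less inhibition), compound 1 gives 90%, the higher of the two numbers that were obtained. In this assay compound 2 gives 78%, a result that lies below that of compound 1 by more than the usual scatter. For compound 3 this assay holds only "not determined" (no result reported), so nothing can be said of how it compares.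

Compound 4 `NC(N)=NC(=O)c1nc(Cl)c(NCc2ccccc2F)nc1N` differs from compound 1 in a single place: fluoro in place of chloro on an aromatic carbon. Among the compounds with values here, no pair of measured compounds shows this exchange, so it has to be judged from compound 1 alone. Because compound 1 gives 90% and the exchange touches only one atom, the shift is expected to be small, a number 7 percentage points lower from compound 1 to compound 4 (within the scatter), downward if anything and probably within the scatter. Compound 4 is thus estimated to give about 83% in this assay, with a likely range from 65% to 95%.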

Compound 4, a percentage reported as inhibition, at one concentration (the size of the read-out at that concentration, not a potency): 92%
Compound 4: the middle estimate sits 9 percentage points below what was measured; low and high end bracket the measured number.
By their numbers in this assay, from the lowest: compound 2; then compounds 1 and 4 (each within the scatter of the next).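

Going from 2-chlorophenyl to 2-fluorophenyl on the benzyl arm, this assay shows a number 2 percentage points higher from compound 1 to compound 4 (within the scatter), so at this place, on an aromatic carbon ortho to a large group, the two halogens cannot be told apart by this read-out. Within the data shown here, the earlier compounds held no pair differing by a single atom on this arm, so this step is the first direct view of how the read-out responds to a change this small, and the inhibition stays high with either halogen. Since the read-out gives the size of inhibition at one concentration and not a potency, the step says nothing about whether the two compounds would also match at lower concentrations, and nothing available here bears on why the two halogens read alike.

From the compounds shown here alone, whether this place accepts a group other than a halogen, such as methoxy, a nitrile or an amine, remains open, as does how the arm would read with plain hydrogen there. Also open, going by these compounds, is whether fluoro would match chloro at another carbon of the same ring.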